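A Fluorophenyl Piperazine Variant in a Cytotoxicity Series

The compounds below may be only part of what the source reports. "The series", "measured", "known", "first", "only" and "open" are said of these compounds alone.

Measured in a functional assay on DU-145 cells (Homo sapiens) for cytotoxicity, read by sulforhodamine B assay, with a stated time of 48 h; on this read-out higher numbers stand for weaker inhibition of growth and lower numbers for stronger inhibition of growth:
Compound 1 `CC1CC(C)CN(c2nc(Nc3ccc(C#N)c(C(F)(F)F)c3)nc(Oc3ccnc4ccccc34)n2)C1` gives 68000 nM.
Compound 2 `CN1CCN(c2nc(Nc3ccc(C#N)c(C(F)(F)F)c3)nc(Oc3ccnc4ccccc34)n2)CC1` gives only a limit, > 100000 nM.
Compound 3 `N#Cc1ccc(Nc2nc(Oc3ccnc4ccccc34)nc(N3CCC(Cc4ccccc4)CC3)n2)cc1C(F)(F)F` likewise gives only a limit, > 100000 nM.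

Compound 2 thus stands at the edge of what this assay reports, with no number of its own; compound 3 sits at the same edge, while compound 1 is the only one of the three with a measured number. Going by the values given here, the single step within this set, an at least 1.4-fold higher number from compound 1 to compound 2 (0.16 log units; that floor lies within the scatter), runs toward that edge, and its floor lies within the scatter, so it settles little.

The new compound 4 `N#Cc1ccc(Nc2nc(Oc3ccnc4ccccc34)nc(N3CCN(c4ccccc4F)CC3)n2)cc1C(F)(F)F` arises from compound 2 by a change on the ring: 2-fluorophenyl in place of methyl on an amine nitrogen in a ring. Compound 3, which also carries a large group on its ring, shows only the limit, and the limit of > 100000 nM in this assay, at which 2 of the 3 values shown sit, marks where most of the values in this set sit. Among the compounds with values here, with no measured step in which a ring nitrogen gains an aromatic ring, the expectation for compound 4 rests on the weak activity of all three measured compounds and is that the step of an at least 1.1-fold lower number from compound 2 to compound 4 (0.04 log units; that floor lies within the scatter) adds nothing beyond the scatter. Compound 4 is therefore estimated at 90000 nM, within a range from 35000 nM to 250000 nM, with a fair chance that only a limit is reported.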

Compound 4, concentration for total growth inhibition: > 100000 nM
Compound 4: no number, only a limit (the forecaster's own chance of this, stated with the estimate: 55%); middle value at least 1.1-fold (0.04 log units) from the limit.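

Compound 2 and compound 4 both give only a limit in this assay, so the step between them cannot be read. The compounds shown leave open whether 2-fluorophenyl in place of methyl on an amine nitrogen in a ring changes growth inhibition at all.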